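A few compounds are considered here, and "the series" means these few. Any claim that something is new, unique, unknown or untested is made for them only; others in the source may bear on it.

Of the compounds shown here, three have been tested in a functional assay on cells (Cancer cell lines, Homo sapiens) for cytotoxicity, read by sulforhodamine B assay, with a stated time of 48 h; on this read-out higher numbers stand for weaker inhibition of growth and lower numbers for stronger inhibition of growth. Compound 1 `COc1ccc(C2CC(c3ccccc3)=NN2C2=NC(=O)/C(=C3\C(=O)Nc4ccc(Br)cc43)S2)cc1` gives 480 nM, and compound 2 `COc1ccc(C2=NN(C3=NC(=O)/C(=C4\C(=O)Nc5ccc(Br)cc54)S3)C(c3ccc(OC)cc3)C2)cc1` gives 480 nM; the only difference between them is a methoxy group in place of a hydrogen on an aromatic carbon, and no change at the digits printed from compound 1 to compound 2 (within the scatter). Compound 3 `COc1ccc(C2CC(c3ccc4ccccc4c3)=NN2C2=NC(=O)/C(=C3\C(=O)Nc4ccccc43)S2)cc1` gives 32800 nM, the highest number of the three and therefore the weakest growth inhibition among them, standing far away from both compound 1 and compound 2.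

Compound 4 `COc1ccc(C2CC(c3ccc4ccccc4c3)=NN2C2=NC(=O)/C(=C3\C(=O)Nc4ccc(Br)cc43)S2)cc1` has not yet been measured in this assay. It differs from compound 3 by one change: bromo in place of hydrogen on an aromatic carbon. Among the measured compounds shown here, none of the measured pairs isolates this exact change, since compound 1 and compound 2 carry bromo on the same ring but also carry a different group on the other end of the molecule than compound 3 does. The measured step from compound 1 to compound 2 concerns a different position and does not bear on it. What is known is that the two compounds carrying bromo sit at low numbers, while compound 3, lacking it, sits at a high one.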

Compound 4, concentration for total growth inhibition: 990 nM
For compound 4 the middle estimate is 6.1-fold (0.78 log units) above the measured one, and the stated range covers the measured number.
By their numbers in this assay, from the lowest: compounds 1 and 2 (each within the scatter of the next); then compound 4; then compound 3.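

In this assay, bromo in place of hydrogen on an aromatic carbon of the fused system of two rings gives a 33-fold lower number from compound 3 to compound 4 (1.52 log units; beyond the scatter), so this single change is now seen on its own as a large gain in growth inhibition. With bromo present, naphthalen-2-yl in place of phenyl gives a 2.1-fold higher number from compound 1 to compound 4 (0.31 log units; beyond the scatter) and naphthalen-2-yl in place of 4-methoxyphenyl gives a 2.1-fold higher number from compound 2 to compound 4 (0.31 log units; beyond the scatter), and both of these modest steps are much smaller than the step from adding bromo. Nothing measured here explains why bromo has this effect.

The compounds shown leave open whether bromo brings a similar gain when phenyl or 4-methoxyphenyl stands in place of naphthalen-2-yl. They also leave open how chloro, methoxy or an amine would behave on the same aromatic carbon.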